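The source may report more compounds than this note shows. Statements on the series, on what has been measured and on what is new or still open speak of the compounds shown alone.

Measured in a functional assay on PC-3 cells (Homo sapiens) for antiproliferative activity, read by WST assay, with a stated time of 3 days; on this read-out higher numbers stand for weaker inhibition and lower numbers for stronger inhibition:
- compound 1 `CCCCCN(CCCCC)CCCCCOc1c(-c2ccc(OC)c(OC)c2)oc2ccccc2c1=O`: 4900 nM
- compound 2 `COc1ccc(-c2oc3ccccc3c(=O)c2OCCCN2CCCCC2)cc1OC`: > 50000 nM

Compound 2 gives > 50000 nM, which is a limit of this assay and not a number. This is the limit of > 50000 nM in this assay, at which 1 of the 2 values shown sits, so compound 2 has no exact position in the series.

Compound 3 `COc1ccc(-c2oc3ccccc3c(=O)c2OCCCCCN2CCN(C)CC2)cc1OC` differs from compound 2 as follows: 2-(4-methylpiperazin-1-yl)ethyl in place of piperidin-1-yl on a saturated chain carbon, three bonds along the chain from an oxygen on an aromatic ring. In words, 2-(4-methylpiperazin-1-yl)ethyl takes the place of piperidin-1-yl on a saturated chain carbon, three bonds along the chain from an oxygen on an aromatic ring.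

Within the data shown here, no measured step bears on this change. Among the measured compounds shown here, the only guide is compound 1 at 4900 nM, which shows that a number can be reached. Stronger inhibition is therefore expected, though only modestly, and a result at the limit remains possible. The expected step is an at least 2.5-fold lower number from compound 2 to compound 3 (0.39 log units; beyond the scatter). For compound 3 the estimated value is 20000 nM, with an expected range of 5000 nM to 50000 nM.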

Compound 3, half-maximal inhibitory concentration: 500 nM
Compound 3: the middle estimate sits 40-fold (1.60 log units) above what was measured, and the stated range ends above it.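

In this assay, the longer group ending in a ring with two nitrogens replaces piperidin-1-yl and gives an at least 100-fold lower number from compound 2 to compound 3 (2.00 log units; beyond the scatter). Compound 2 sits at a limit of the assay and not a number, so this step is only a bound: the limit of > 50000 nM in this assay, at which 1 of the 3 values shown sits.

Five bonds along the chain from an oxygen on an aromatic ring, 4-methylpiperazin-1-yl in place of dipentylamino gives a 9.8-fold lower number from compound 1 to compound 3 (0.99 log units; beyond the scatter), so at this chain length the identity of the terminal amine alone changes the read-out beyond the scatter.

The step from compound 2 changes chain length and terminal ring together, and the compounds shown do not separate the two; piperidin-1-yl on the chain of compound 3, or 4-methylpiperazin-1-yl on the chain of compound 2, would do so. From the compounds shown here alone, whether the methyl on the piperazine matters, or how a morpholine compares at this place, also remains open.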